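The compounds below may be only part of what the source reports. "The series", "measured", "known", "first", "only" and "open" are said of these compounds alone.

Measured so far:
- compound 1 `COC1=C(C)C(=O)/C(=C(O)/C=C/c2ccc(F)cc2)C(=O)C1(C)C`: 3.7 ug/mL
- compound 2 `COC1=C(C)C(=O)/C(=C(O)/C=C/c2ccccc2C)C(=O)C1(C)C`: 4.1 ug/mL
- compound 3 `COC1=C(C)C(=O)/C(=C(O)/C=C/c2cc(C)cc(C)c2)C(=O)C1(C)C`: 3.1 ug/mL

In a functional assay on KB cells (Homo sapiens) for cytotoxicity (a lower number here means that less compound is needed, a higher number that more compound is needed for the effect), compound 1 gives 3.7 ug/mL, which stands within the scatter of both other compounds. Next comes compound 4 `COC1=C(C)C(=O)/C(=C(O)/C=C/c2cccs2)C(=O)C1(C)C`, with thiophen-2-yl in place of 4-fluorophenyl on a double-bonded chain carbon bound to a double-bonded chain carbon.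

Three measured steps change the group at this same place: a 1.1-fold higher number from compound 1 to compound 2 (0.04 log units; within the scatter), a 1.2-fold lower number from compound 1 to compound 3 (0.08 log units; within the scatter) and a 1.3-fold lower number from compound 2 to compound 3 (0.12 log units; within the scatter). All three are small and exchange one substituted phenyl for another. None of them brings in a five-membered aromatic ring or sulfur, so they bear on compound 4 only indirectly, and the range is kept wider than these steps alone suggest.

The estimated change is a 1.1-fold lower number from compound 1 to compound 4 (0.02 log units; within the scatter), so no step beyond the scatter is expected in this assay. For compound 4 the expected value is 3.5 ug/mL, with an estimated range of 2 ug/mL to 6.5 ug/mL.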

Compound 4, concentration for half-maximal effect: 5.5 ug/mL
Estimate against measurement, compound 4: 1.6-fold (0.20 log units) below; the range from low to high includes it.
By their numbers in this assay, from the lowest: compounds 3, 1, 2 and 4 (each within the scatter of the next).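

In this assay, thiophen-2-yl in place of the substituted phenyl groups gives three steps (a 1.5-fold higher number from compound 1 to compound 4 (0.17 log units; within the scatter)) (a 1.3-fold higher number from compound 2 to compound 4 (0.13 log units; within the scatter)) (a 1.8-fold higher number from compound 3 to compound 4 (0.25 log units; within the scatter)). For the compounds shown here, all three lie within the scatter, so even a five-membered aromatic ring with a hetero atom, with fewer heavy atoms than 4-fluorophenyl, is not separated from the phenyl groups at this place on a double-bonded chain carbon bound to a double-bonded chain carbon; the earlier steps exchanged only one substituted phenyl for another. No supporting data are available to explain the values or to assign any role to the sulfur.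

Still open, going by these compounds, is whether an amine, a carboxylic acid or a longer chain at this place would give a step beyond the scatter. Also open, on these data alone, is whether furan-2-yl would behave like thiophen-2-yl here.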